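Working notes: methyl to hydroxy on the aryl ring

The compounds below may be only part of what the source reports. "The series", "measured", "known", "first", "only" and "open" are said of these compounds alone.

Measured in a functional assay on NCI/ADR cells (Homo sapiens) for cytotoxicity, read by sulforhodamine B assay; on this read-out higher numbers stand for weaker inhibition of growth and lower numbers for stronger inhibition of growth:
Compound 1 `CC1=CC[C@@H]([C@@](C)(O)CCCC(C)(C)NC(=S)N/N=C\c2ccccc2)CC1`: 6970 nM
Compound 2 `CC1=CC[C@@H]([C@@](C)(O)CCCC(C)(C)NC(=S)N/N=C\c2ccc(C)cc2)CC1`: 6510 nM

Compound 2 stands alongside compound 1 in this assay; the step of a 1.1-fold lower number from compound 1 to compound 2 (0.03 log units; within the scatter) lies within the scatter, so the two are not told apart. Compound 3 `CC1=CC[C@@H]([C@@](C)(O)CCCC(C)(C)NC(=S)N/N=C\c2ccc(O)cc2)CC1` differs from compound 2 by hydroxy in place of methyl on an aromatic carbon. For the measured compounds named here, no measured step covers a hydroxy here; the only step at this carbon, a 1.1-fold lower number from compound 1 to compound 2 (0.03 log units; within the scatter), was flat. In this assay, going by these compounds, a step of no size beyond the scatter is therefore expected, a 1.0-fold lower number from compound 2 to compound 3 (0.00 log units; within the scatter), with a wide range because the entering group is untested. For compound 3 the estimate is 6500 nM, between 2500 nM and 17000 nM.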

Compound 3, concentration for 50% growth inhibition: 8390 nM
The estimate for compound 3 lay 1.3-fold (0.11 log units) below the measured number; measured number inside the range.
By their numbers in this assay, from the lowest: compounds 2, 1 and 3 (each within the scatter of the next).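

In this assay, hydroxy at this carbon gives a 1.3-fold higher number from compound 2 to compound 3 (0.11 log units; within the scatter) and a 1.2-fold higher number from compound 1 to compound 3 (0.08 log units; within the scatter), so hydrogen, methyl and hydroxy are not told apart here. The flat picture, so far resting on methyl alone, now also covers an entering group with a hydrogen-bond donor and acceptor. No evidence on hand accounts for this flatness. Still open, going by these compounds, is whether an amine, a carboxylic acid or a longer chain on this carbon would give a step beyond the scatter. Also open, on these data alone, is whether the flat picture holds with changes elsewhere on the shared core.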